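The source may hold more compounds than are shown below. What is called first, only, known or untested is meant among the compounds shown, and "the series" means these compounds.

Measured so far in an ADME assay on Vero cells (Chlorocebus sabaeus) for cytotoxicity, read by neutral red uptake, with a stated time of 48 h (a higher number here means a weaker inhibitor, a lower number a stronger inhibitor), as limits only:
- compound 1 `CCN(CC)c1nc(Cl)nc2c1ncn2CCNc1ccnc2cc(Cl)ccc12` with > 11000 nM as a limit
- compound 2 `Clc1ccc2c(NCCn3cnc4c(N5CCCC5)nc(Cl)nc43)ccnc2c1` with > 11100 nM as a limit
- compound 3 `CCN1CCN(c2nc(Cl)nc3c2ncn3CCNc2ccnc3cc(Cl)ccc23)CC1` with > 10100 nM as a limit

For compound 3 there is only the limit of > 10100 nM in this assay, at which 1 of the 3 values shown sits, and no number. Compound 1 and compound 2 also give limits only.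

Compound 4 `Clc1ccc2c(NCCn3cnc4c(N5CCN(c6ccccc6)CC5)nc(Cl)nc43)ccnc2c1` differs from compound 3 in one place: phenyl in place of ethyl on an amine nitrogen in a ring. Of the measured steps, a step that the two limits leave unreadable from compound 1 to compound 3 and a step that the two limits leave unreadable from compound 2 to compound 3 bear most closely on it and give no size to carry over. The expected change in this assay is an at least 1.0-fold lower number from compound 3 to compound 4 (0.02 log units; that floor lies within the scatter) (none beyond the scatter, no direction readable). Another limit is the likeliest result. For compound 4 the estimated value is 9500 nM (expected range 4000 nM to 20000 nM).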

Compound 4, half-maximal inhibitory concentration: 4040 nM
The estimate for compound 4 lay 2.4-fold (0.37 log units) above the measured number; the range from low to high includes it.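

In this assay, within the data shown here, phenyl in place of ethyl on the ring amine nitrogen gives the first readable number at this position, with an at least 2.5-fold lower number from compound 3 to compound 4 (0.39 log units; beyond the scatter). 4-Phenylpiperazin-1-yl also gives an at least 2.7-fold lower number from compound 2 to compound 4 (0.43 log units; beyond the scatter) and an at least 2.7-fold lower number from compound 1 to compound 4 (0.43 log units; beyond the scatter), whereas the steps among compound 1, compound 2 and compound 3 cannot be read. Compound 3 has only a limit, which leaves the full size of its step open: the limit of > 10100 nM in this assay, at which 1 of the 4 values shown sits.

On these data alone, whether the lower number follows the aromatic ring or the carbon count remains open. Cyclohexyl or benzyl on the same nitrogen would separate the two.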